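A few compounds are considered here, and "the series" means these few. Any claim that something is new, unique, unknown or untested is made for them only; others in the source may bear on it.

Three compounds share a common core carrying two hydroxy groups and a nitro group. In an assay for inhibition of Catechol O-methyltransferase (Rattus norvegicus), read by fluorescence and spectrophotometry (on this read-out lower numbers stand for stronger inhibition and higher numbers for weaker inhibition), compound 1 `N#Cc1cccc(/C=C/C(=O)c2cc(O)c(O)c([N+](=O)[O-])c2)c1` gives 240 nM, compound 2 `O=C(/C=C/c1cccc(O)c1)c1cc(O)c(O)c([N+](=O)[O-])c1` gives 140 nM, and compound 3 `CC(=O)N1N=C(c2cc(O)c(O)c([N+](=O)[O-])c2)CC1c1cccs1` gives 210 nM. Compound 3 stands second highest of these three numbers, within the scatter of both others. For the measured compounds named here, the only measured step, a 1.7-fold lower number from compound 1 to compound 2 (0.23 log units; within the scatter), concerns a different part of the molecules and so does not bear on the change to compound 4 `CC(=O)N1N=C(c2cc(O)c(O)c([N+](=O)[O-])c2)CC1c1ccoc1`, which is furan-3-yl in place of thiophen-2-yl on a saturated ring carbon. Going by the values given here, since no measured step speaks to exchanging one five-membered aromatic ring for another, no shift beyond the scatter is expected, and compound 4 is estimated at about 210 nM, between 100 nM and 450 nM, an expected step of no change at the digits printed from compound 3 to compound 4 (within the scatter).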

Compound 4, half-maximal inhibitory concentration: 180 nM
Beside the measured number, compound 4's estimate is 1.2-fold (0.07 log units) above it; low and high end bracket the measured number.
By their numbers in this assay, from the lowest: compounds 2, 4, 3 and 1 (each within the scatter of the next).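

In this assay, furan-3-yl in place of thiophen-2-yl on the saturated ring carbon gives a 1.2-fold lower number from compound 3 to compound 4 (0.07 log units; within the scatter) and so leaves the reading unchanged within the scatter. For the compounds shown here, this is the first measured step at this position, and it shows that sulfur can give way to oxygen, with the ring's point of attachment altered at the same time, without a difference this assay can separate. Going by these compounds, whether a cyclohexyl ring, a methyl group or an aminomethyl group on this carbon would shift the number beyond the scatter remains open. Nothing available explains why these two rings read alike.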